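The source may report more compounds than this note shows. Statements on the series, on what has been measured and on what is new or still open speak of the compounds shown alone.

Compound 1 `Cc1cnc(Nc2ccc(C(C)C)cc2)nc1Nc1nc2ccccc2s1` gives > 50000 nM in a functional assay on MCF7 cells (Homo sapiens) for antiproliferative activity, read by MTT assay, with a stated time of 48 h (on this read-out higher numbers stand for weaker inhibition and lower numbers for stronger inhibition), which is a limit of the assay and not a number.
Compound 2 `Cc1cnc(Nc2ccc([N+](=O)[O-])cc2)nc1Nc1nc2ccccc2s1` gives > 50000 nM in this assay, again a limit and not a number.

Both values sit at the same edge of the assay, (the limit of > 50000 nM in this assay, at which 2 of the 2 values shown sit), so the step that the two limits leave unreadable from compound 1 to compound 2 cannot be read. Compound 2 thus stands at the limit, with no number of its own to place it against anything else. Compound 3 `Cc1cnc(Nc2ccc(S(N)(=O)=O)cc2)nc1Nc1nc2ccccc2s1` differs from compound 2 by sulfamoyl in place of nitro on an aromatic carbon. Going by the values given here, the only measured step bears on the same place on the ring but is unreadable, so it sets no size and no direction for this change, and the two limits give no sign that a change at this place moves the read-out into the measurable range. Compound 3 is therefore expected to remain at the limit as well, with an estimated value of 70000 nM (range 20000 nM to 200000 nM). The expected step that the limit leaves unreadable from compound 2 to compound 3 is meant as no change beyond the scatter.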

Compound 3, half-maximal inhibitory concentration: > 50000 nM
Compound 3 gave a limit, no number; the forecaster's own chance of this, stated with the estimate: 80%; the middle value is on the limit's open side.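

Compound 3 gives > 50000 nM in this assay, a limit and not a number. Going by these compounds alone, no step among compound 1, compound 2 and compound 3 can therefore be read: the limit of > 50000 nM in this assay, at which 3 of the 3 values shown sit. The compounds shown leave open whether any group at this place brings the read-out into the measurable range.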